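Swapping the Benzyl Group on a Shared Core

The source may hold more compounds than are shown below. What is called first, only, known or untested is meant among the compounds shown, and "the series" means these compounds.

Of the compounds shown here, three on one core have been measured in a functional assay on LOX IMVI cells (Homo sapiens) for inhibition, read by sulforhodamine B assay, with a stated time of 48 h; a lower number here means a stronger inhibitor of growth, a higher number a weaker inhibitor of growth. Compound 1, `Nc1cc(N)c2nc(-c3ccccc3)c(NCc3ccc(Cl)c(Cl)c3)nc2c1`, gives 2140 nM in this assay. Compound 2, `CCOC(=O)[C@H](CCC(=O)O)NC(=O)c1ccc(Sc2nc3cc(N)cc(N)c3nc2-c2ccccc2)cc1`, gives 3020 nM in this assay, and the two numbers lie within the usual scatter of each other, so compound 1 holds the smaller of the two numbers without the gap meaning a real difference. Compound 3, `CCOC(=O)[C@H](CCC(=O)O)NC(=O)c1ccc(CNc2nc3cc(N)cc(N)c3nc2-c2ccccc2)cc1`, gives in this assay only a limit, < 100000 nM, which is a bound of the assay and not a number; this is the one case where (the limit of < 100000 nM in this assay, at which 1 of the 3 values shown sits).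

Compound 4, `COc1ccc(CNc2nc3cc(N)cc(N)c3nc2-c2ccccc2)cc1`, has not yet been measured. It differs from compound 1 in a single place: 4-methoxyphenyl in place of 3,4-dichlorophenyl on a saturated chain carbon bound to a nitrogen on an aromatic ring. Among the compounds with values here, no measured pair in this set follows the same change, so the expected step rests on the change itself and on the spread of the three values already in hand. Compound 4 is estimated to give 5000 nM in this assay, with a range from 1500 nM to 20000 nM. This estimate means a step from compound 1 to compound 4 of a 2.3-fold higher number from compound 1 to compound 4 (0.37 log units; beyond the scatter), a modest loss expected in this assay that may still fall within the scatter.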

Compound 4, concentration for 50% growth inhibition: 13500 nM
For compound 4 the middle estimate is 2.7-fold (0.43 log units) below the measured one; low and high end bracket the measured number.
By their numbers in this assay, from the lowest: compounds 1 and 2 (each within the scatter of the next); then compound 4.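

In this assay, the step of a 6.3-fold higher number from compound 1 to compound 4 (0.80 log units; beyond the scatter) shows that this place on the shared core is sensitive to what the ring carries: 4-methoxyphenyl does not stand in for 3,4-dichlorophenyl on a saturated chain carbon bound to a nitrogen on an aromatic ring. Within the data shown here, it is the first step in the set that can be read between compounds differing in one place, and the two groups it joins match in heavy atoms and in their six-membered aromatic ring of carbon only, yet the step still lies beyond the scatter. They differ in the chlorine and oxygen they carry and in the one hydrogen-bond acceptor that enters with 4-methoxyphenyl, but nothing measured here bears on the cause of this step.

The compounds shown leave open whether the step follows the chlorine atoms that leave or the methoxy group that enters, a question that a ring with a single chlorine or an unsubstituted phenyl ring on the same chain carbon would address. They also leave open how this place responds to quite different groups, such as a carboxylic acid or an amine on the ring.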